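The source may hold more compounds than are shown below. What is called first, only, known or untested is meant among the compounds shown, and "the series" means these compounds.

Values in an ADME assay on HOS cells (Homo sapiens) for cytotoxicity; on this read-out higher numbers stand for lower toxicity in this test and lower numbers for higher toxicity in this test:
Compound 1 `CN(Cc1nc2ccccc2n1CCN)C1CCCc2cccnc21`: > 20000 nM, a limit.
Compound 2 `CN(Cc1nc2ccccc2n1CCCCN)C1CCCc2cccnc21`: 2900 nM.
Compound 3 `CN(Cc1nc2cccc(C(=O)NCCCN)c2[nH]1)C1CCCc2cccnc21`: > 20000 nM, a limit.

Compound 3 stands at > 20000 nM, which is a limit and not a number. Most of the series shares that position: the limit of > 20000 nM in this assay, at which 2 of the 3 values shown sit. Compound 4 `CN(Cc1nc2cccc(CCCN3CCCC3)c2[nH]1)C1CCCc2cccnc21` carries the change (3-(pyrrolidin-1-yl)propyl in place of (3-aminopropyl)carbamoyl on an aromatic carbon). Within the data shown here, the one measured step, an at least 6.8-fold lower number from compound 1 to compound 2 (0.83 log units; beyond the scatter), is a different change at a different place (2-aminoethyl in place of amino on a saturated chain carbon), so it bears only loosely here. On that step, a move to a lower number is expected, of similar or smaller size. The expected step is an at least 1.8-fold lower number from compound 3 to compound 4 (0.25 log units; that floor lies within the scatter). For compound 4 the estimated value is 11000 nM, with an expected range of 4000 nM to 25000 nM.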

Compound 4, half-maximal cytotoxic concentration: 8200 nM
Estimate against measurement, compound 4: 1.3-fold (0.13 log units) above; measured number inside the range.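

In this assay, 3-(pyrrolidin-1-yl)propyl in place of (3-aminopropyl)carbamoyl on this aromatic carbon gives an at least 2.4-fold lower number from compound 3 to compound 4 (0.38 log units; beyond the scatter), so a change here, and not only on the chain of compound 1 and compound 2, moves the read-out. Compound 3 gives > 20000 nM, which is a limit, so the size of this step is only a floor. Compound 4 stands off the limit shared by other members of the series: the limit of > 20000 nM in this assay, at which 2 of the 4 values shown sit.

As far as these compounds go, it remains open whether the step follows the loss of the carbonyl or the arrival of the pyrrolidine ring. A plain 3-aminopropyl chain or a piperidine ring at this aromatic carbon would separate the two.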